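Removing the hydroxy from compound 2: an expected flat step

The compounds below may be only part of what the source reports. "The series", "measured", "known", "first", "only" and "open" are said of these compounds alone.

Compound 2 `Cc1nc2c3ccccc3ccc2c2nc3c(ccc4ccccc43)c(-c3ccc(O)cc3)c12` gives 86.4 ug/mL in a functional assay, read by spectrophotometry, with a stated time of 30 min (a higher number here means a weaker inhibitor, a lower number a stronger inhibitor), and compound 1 `Cc1nc2c3ccccc3ccc2c2nc3c(ccc4ccccc43)c(-c3cccnc3)c12` gives 98.2 ug/mL. For the measured compounds named here, these two numbers sit within the scatter of each other, so neither can be called the stronger; the only measured step, a 1.1-fold lower number from compound 1 to compound 2 (0.06 log units; within the scatter), was itself within the scatter. Compound 3 `Cc1nc2c3ccccc3ccc2c2nc3c(ccc4ccccc43)c(-c3ccccc3)c12` differs from compound 2 by hydrogen in place of hydroxy on an aromatic carbon. Going by the values given here, no measured step removes a hydroxy, and the single step known was flat, so the step of a 1.0-fold higher number from compound 2 to compound 3 (0.02 log units; within the scatter) is expected to stay within the scatter. Compound 3 is therefore estimated at 90 ug/mL, with a range from 45 ug/mL to 180 ug/mL.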

Compound 3, half-maximal inhibitory concentration: 164 ug/mL
Estimate against measurement, compound 3: 1.8-fold (0.26 log units) below, and the stated range covers the measured number.
By their numbers in this assay, from the lowest: compounds 2, 1 and 3 (each within the scatter of the next).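

In this assay there is a 1.9-fold higher number from compound 2 to compound 3 (0.28 log units; within the scatter) when hydrogen takes the place of hydroxy, so the hydroxy is not shown to matter at this position, even though this step is wider than the first one measured. Phenyl in place of pyridin-3-yl gives a 1.7-fold higher number from compound 1 to compound 3 (0.22 log units; within the scatter) as well, so none of the three groups on this aromatic carbon can be told apart here. No evidence bearing on this result is available.

Still open, going by these compounds, is whether an amine or a carboxylic acid on this ring would move the number beyond the scatter. The same holds for a longer chain at this position.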